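The source may report more compounds than this note shows. Statements on the series, on what has been measured and on what is new or still open speak of the compounds shown alone.

Three amides on the shared core have been run in an ADME assay on HepG2 cells (Homo sapiens) for inhibition, with a stated time of 48 h (a lower number here means that less compound is needed, a higher number that more compound is needed for the effect), and none of them gave a number. Compound 1 `CCN(CC)C(=O)C(C)N1CCN(S(=O)(=O)c2ccc(C(C)(C)C)cc2)CC1` returns only a limit of the assay, > 40000 nM. Compound 2 `CC(C(=O)N1CCN(C)CC1)N1CCN(S(=O)(=O)c2ccc(C(C)(C)C)cc2)CC1` likewise returns only a limit, > 40000 nM. Compound 3 `CC(C(=O)N(C)Cc1ccccc1)N1CCN(S(=O)(=O)c2ccc(C(C)(C)C)cc2)CC1` also stands at a limit, > 40000 nM. The exchanges at the carbonyl carbon among these three cannot be sized: a step that the two limits leave unreadable from compound 1 to compound 2, a step that the two limits leave unreadable from compound 1 to compound 3 and a step that the two limits leave unreadable from compound 2 to compound 3 all remain unreadable because of the limit of > 40000 nM in this assay, at which 3 of the 3 values shown sit.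

Compound 4 `CC(C(=O)N1CCc2cccnc2C1)N1CCN(S(=O)(=O)c2ccc(C(C)(C)C)cc2)CC1` carries a group of 10 heavy atoms (8 carbon, 2 nitrogen; one six-membered non-aromatic ring with 1 hetero atom, one six-membered aromatic ring with 1 hetero atom) in place of a group of 9 heavy atoms (8 carbon, 1 nitrogen; one six-membered aromatic ring of carbon only), on a carbonyl carbon. The measured steps that bear on this change are the three amine exchanges at the same carbonyl carbon, and every one of them was unreadable, so they give neither a direction nor a size in this assay. What the series does show is that three different amide groups at this position all failed to reach a measurable value. On that basis the step from compound 3 to compound 4 is expected to be nil within the scatter, a number no higher from compound 3 to compound 4 (the limit leaves the size open), with a further limit the most likely outcome. Compound 4 is therefore estimated at 40000 nM, with a range from 15000 nM to 120000 nM.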

Compound 4, half-maximal effective concentration: > 40000 nM
Compound 4 gave a limit, no number (the forecaster's own chance of this, stated with the estimate: 80%); the middle value sits exactly at the limit.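

Compound 4 gives only a limit in this assay, so its steps from compound 1, compound 2 and compound 3 cannot be read, because all four compounds stand at the same limit: the limit of > 40000 nM in this assay, at which 4 of the 4 values shown sit.

The compounds shown leave open whether any amide on this carbonyl carbon reaches a measurable value in this assay and how far apart these four compounds lie.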